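A few compounds are considered here, and "the series" means these few. Any claim that something is new, unique, unknown or untested is made for them only; others in the source may bear on it.

Measured compounds, all in a functional assay on Hs-578T cells (Homo sapiens) for inhibition, read by sulforhodamine B assay, with a stated time of 48 h, tested at 10 uM; a higher number here means more inhibition at the concentration tested (going by the name of the read-out), a lower number less inhibition:
Compound 1, `Brc1ccc(-c2cn3ccnc3c(-c3ccc4ncn(C5CCCCC5)c4c3)n2)cc1`, gives 24.5%.
Compound 2, `Fc1ccccc1-c1cn2ccnc2c(-c2ccc3ncn(C4CCCCC4)c3c2)n1`, gives 5.26%.
Compound 3, `c1cn2cc(-c3ccc4c(c3)ncn4C3CCCCC3)nc(-c3ccc4ncn(C5CCCCC5)c4c3)c2n1`, gives 23.6%.

Compound 3 stands second highest of the three numbers in this assay. Its nearest neighbour is compound 1, whose number is higher by an amount within the scatter, so the two cannot be told apart on these data. Compound 2 lies furthest away, beyond the scatter below compound 3. Among the measured compounds shown here, the only step that can be followed between two measured compounds differing in a single place is a number 19.2 percentage points lower from compound 1 to compound 2 (beyond the scatter); it concerns the aryl group on an aromatic carbon, not the substituent on the ring nitrogen.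

Compound 4, `c1ccc(Cn2cnc3ccc(-c4nc(-c5ccc6c(c5)ncn6C5CCCCC5)cn5ccnc45)cc32)cc1`, is not yet measured. It differs from compound 3 by benzyl in place of cyclohexyl on an aromatic nitrogen. For the measured compounds named here, no measured pair changes the group on the aromatic nitrogen; every measured compound carries cyclohexyl there. The step from compound 1 to compound 2 is at a different place and does not inform this change, and nothing else in the numbers points in either direction. The expected step is a number 0.4 percentage points higher from compound 3 to compound 4 (within the scatter), that is, none beyond the scatter. Compound 4 is accordingly estimated at 24% in this assay, with a range from 5% to 45%.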

Compound 4, a percentage reported as inhibition, at one concentration (the size of the read-out at that concentration, not a potency): 99.6%
Estimate against measurement, compound 4: 75.6 percentage points below; measured number above the stated range.
By their numbers in this assay, from the lowest: compound 2; then compounds 3 and 1 (each within the scatter of the next); then compound 4.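

Notes on the group on the aromatic nitrogen: benzyl in place of cyclohexyl gives a number 76 percentage points higher from compound 3 to compound 4 (beyond the scatter) in this assay and is the first change read at this position, so the substituent on this ring nitrogen can move the read-out strongly in this series. Among the compounds shown here, until now, the only step that could be followed was at a different place, a number 19.2 percentage points lower from compound 1 to compound 2 (beyond the scatter) in this assay, and every earlier compound carried cyclohexyl on the ring nitrogen, so they gave no sign of this sensitivity. The change swaps a non-aromatic carbon ring for an aromatic one and goes from 6 to 7 heavy atoms, but no measurement at hand accounts for the step.

Open, going by these compounds, is whether the aromatic ring, the single carbon linking it to the nitrogen, or both carry the effect, which cyclohexylmethyl, phenyl or phenethyl on the same nitrogen would help to separate. Also open, on these data alone, are the effect of benzyl in place of the remaining cyclohexyl, of a methoxy group or an amine on the benzyl ring, and how the effect of compound 4 changes at other concentrations.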